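Aryl swap on the lactam nitrogen of a chlorophenyl oxadiazole series

This account rests on a few compounds, and the source may have more. Where it says the series, first, only, none or still open, it means among the compounds named here.

Measured so far:
- compound 1, `C[C@H](c1ccccc1)N1C[C@H](c2nc(-c3cccc(Cl)c3)no2)CC1=O`, 1600 nM
- compound 2, `O=c1oc2ccccc2n1Cc1nc(-c2cccc(Cl)c2)no1`, 2100 nM
- compound 3, `Cc1ccccc1N1CC(c2nc(-c3cccc(Cl)c3)no2)CC1=O`, 370 nM

These three compounds were tested in an in vitro functional assay on HEK293-A cells for negative allosteric modulation of metabotropic glutamate receptor 5 (Homo sapiens), read by FLIPR and calcium flux; a lower number here means a stronger inhibitor, a higher number a weaker inhibitor. Among them compound 3 stands lowest, and its gap to each of the other two lies beyond the usual scatter, so it counts as the strongest inhibitor of the three.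

Compound 4, `Cc1ccc(N2CC(c3nc(-c4cccc(Cl)c4)no3)CC2=O)cc1C`, has not yet been measured. It differs from compound 3 in one place: 3,4-dimethylphenyl in place of 2-methylphenyl on an amide-type nitrogen in a ring.

For the measured compounds named here, no step between two measured compounds shows what such a change does, so the expectation rests on compound 3 alone. A small to moderate loss of potency in this assay is expected, a 1.9-fold higher number from compound 3 to compound 4 (0.28 log units; within the scatter), though staying within the scatter is also possible. Compound 4 is therefore estimated at 700 nM, with a range from 250 nM to 2500 nM.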

Compound 4, half-maximal inhibitory concentration: > 10000 nM
Compound 4 gave a limit, no number (the forecaster's own chance of this, stated with the estimate: 10%); at least 14-fold (1.15 log units) between middle value and limit.
By their numbers in this assay, from the lowest: compound 3; then compounds 1 and 2 (each within the scatter of the next). At a limit, above all of these: compound 4.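

This position on the amide-type nitrogen in a ring proves highly sensitive to the aryl group it carries: 3,4-dimethylphenyl in place of 2-methylphenyl gives an at least 27-fold higher number from compound 3 to compound 4 (1.43 log units; beyond the scatter), a large step. Compound 4 has no number in this assay, only a limit: the limit of > 10000 nM in this assay, at which 1 of the 4 values shown sits.

This single pair cannot show which methyl group of 3,4-dimethylphenyl goes with the loss, or whether the missing 2-methyl group matters more. Going by these compounds, how a plain phenyl or a methoxyphenyl would fare on this nitrogen also remains open.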